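Halogen on the aromatic ring: from compound 2 to compound 3

The source may report more compounds than this note shows. Statements on the series, on what has been measured and on what is new or still open speak of the compounds shown alone.

Values in a functional assay on RAW264.7 cells (Mus musculus) for inhibition; on this read-out higher numbers stand for weaker inhibition and lower numbers for stronger inhibition:
compound 1 `CCOC(=O)C1=CCCCC1S(=O)(=O)Nc1ccc(Cl)cc1F`: 160 nM
compound 2 `CCOC(=O)C1=CCCCC1S(=O)(=O)Nc1ccc(Cl)cc1`: 400 nM

Compound 2 has the higher number of the two, and compound 1 is its nearest neighbour. Compound 3 `CCOC(=O)C1=CCCCC1S(=O)(=O)Nc1ccc(Cl)cc1Cl` differs from compound 2 as follows: chloro in place of hydrogen on an aromatic carbon. Going by the values given here, one measured step bears on this: a 2.5-fold higher number from compound 1 to compound 2 (0.40 log units; beyond the scatter), with fluoro replaced by hydrogen on that same carbon. No chloro at this place has been measured, so the read-across is tentative. A modest move to a lower number is expected: a 3.3-fold lower number from compound 2 to compound 3 (0.52 log units; beyond the scatter). For compound 3 the estimated value is 120 nM, with an expected range of 40 nM to 320 nM.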

Compound 3, half-maximal inhibitory concentration: 20 nM
The estimate for compound 3 lay 6.0-fold (0.78 log units) above the measured number, and the stated range ends above it.
By their numbers in this assay, from the lowest: compound 3; then compound 1; then compound 2.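

In this assay this position proves far more responsive than the fluoro step alone indicated: chloro in place of hydrogen on the aromatic carbon gives a 20-fold lower number from compound 2 to compound 3 (1.30 log units; beyond the scatter). Chloro and fluoro are not interchangeable here either, as replacing fluoro with chloro gives an 8.0-fold lower number from compound 1 to compound 3 (0.90 log units; beyond the scatter). Nothing available accounts for this difference between the two halogens.

Open, on these data alone, is whether bromo, methyl or methoxy at this place would follow chloro. Also open, as far as these compounds go, is whether the gain holds without the chloro group already on the ring.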